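The compounds below may be only part of what the source reports. "The series", "measured", "known", "first", "only" and "open" are said of these compounds alone.

Working notes on the series in a functional assay on the whole organism (Tail, strain ICR) with Mus musculus as the target, in the tail flick test, with a stated time of 30 min, at a dose of 25 umol/kg by the oral route; a higher number here means a stronger effect of the compound at the dose given, a lower number a weaker effect.

Compound 1 `O=C(CN(c1nc(Cl)nc2[nH]cnc12)C1CC1)N[C@@H](CO)C(=O)O` gives 38.7% in this assay. Compound 2 `NC(=O)C[C@H](NC(=O)CN(c1nc(Cl)nc2[nH]cnc12)C1CC1)C(=O)O` gives 29.7% in this assay. Among the compounds with values here, the one step measured so far, a number 9 percentage points lower from compound 1 to compound 2 (within the scatter), does not separate the two compounds; compound 2 stands at a number that lies within the scatter of compound 1, so no ranking between them can be read from the two values.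

Compound 3 `O=C(O)CC[C@H](NC(=O)CN(c1nc(Cl)nc2[nH]cnc12)C1CC1)C(=O)O` has not been measured in this assay. It differs from compound 2 by carboxymethyl in place of carbamoyl on a saturated chain carbon, two bonds along the chain from an amide-type nitrogen and a carbonyl carbon. Within the data shown here, no measured step covers this change; the only step available, a number 9 percentage points lower from compound 1 to compound 2 (within the scatter), concerns the same position but a different exchange, and it was within the scatter. On that basis no step beyond the scatter is expected in this assay, and the number for compound 3 is expected to stay close to that of compound 2, with a number 0.3 percentage points higher from compound 2 to compound 3 (within the scatter) as the estimated step. Compound 3 is thus estimated at 30%, with a range from 15% to 45%.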

Compound 3, a percentage reported as activity, at one dose (the size of the read-out at that dose, not a potency): 26.8%
For compound 3 the middle estimate is 3.2 percentage points above the measured one; measured number inside the range.
By their numbers in this assay, from the lowest: compounds 3, 2 and 1 (each within the scatter of the next, the first and the last beyond it).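

In this assay the exchange of carbamoyl for carboxymethyl on the saturated chain carbon gives a number 2.9 percentage points lower from compound 2 to compound 3 (within the scatter) and so does not separate the two groups at this position. Within the data shown here, the exchange of hydroxy for carboxymethyl at the same place gives a number 11.9 percentage points lower from compound 1 to compound 3 (beyond the scatter) and is the only step that lies beyond the scatter, while compound 2 stays within the scatter of both neighbours. The hydroxy and carboxymethyl compounds can therefore be told apart in this assay only as the two ends of a narrow set, and nothing available accounts for that difference.

The compounds shown leave open how an amine such as aminomethyl, or a plain alkyl group such as methyl, would read at this position, and whether a longer chain ending in a carboxylic acid would stay with compound 3 or move further from compound 1. They also leave open whether the step seen at this single dose and time would hold at other doses or times.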